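A few compounds are considered here, and "the series" means these few. Any claim that something is new, unique, unknown or untested is made for them only; others in the source may bear on it.

Three ureas built on one shared core have been measured for how strongly they block the channel. Compound 1 `Cn1ncc2c(NC(=O)NCc3cc(C(C)(C)C)nn3-c3cccc(Cl)c3)cccc21` carries a tert-butyl group and a 3-chlorophenyl group; in an assay on CHO-K1 cells for antagonist activity at transient receptor potential cation channel subfamily V member 1 (Homo sapiens), read by FLIPR and calcium flux, with a stated time of 6 min (on this read-out higher numbers stand for weaker inhibition and lower numbers for stronger inhibition), compound 1 gives 0.4 nM. Compound 2 `Cn1ncc2c(NC(=O)NCc3cc(C(F)(F)F)nn3-c3ccc(F)c(F)c3)cccc21` carries a trifluoromethyl group and a 3,4-difluorophenyl group, and in this assay compound 2 gives 4.9 nM. Compound 3 `Cn1ncc2c(NC(=O)NCc3cc(C(C)(C)C)nn3-c3ccc(C(F)(F)F)cc3)cccc21` keeps the tert-butyl group but bears a 4-(trifluoromethyl)phenyl group; in this assay compound 3 gives 12.4 nM, the highest of the three numbers, with compound 2 the nearest and compound 1 the furthest away.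

Compound 4 `Cn1ncc2c(NC(=O)NCc3cc(C(C)(C)C)nn3-c3ccc(F)c(F)c3)cccc21` has not yet been measured. It differs from compound 3 in one place: 3,4-difluorophenyl in place of 4-(trifluoromethyl)phenyl on an aromatic nitrogen. Going by the values given here, the only measured step that touches this position is a 31-fold higher number from compound 1 to compound 3 (1.49 log units; beyond the scatter), which shows that the group on this aromatic nitrogen can move the number a long way. Among the compounds with values here, compound 2, the one measured compound that already carries the 3,4-difluorophenyl group, gives a lower number than compound 3, which points toward a decrease. For compound 4 in this assay a clearly lower number than for compound 3 is expected, a step of a 6.2-fold lower number from compound 3 to compound 4 (0.79 log units; beyond the scatter), so compound 4 is estimated at 2 nM, between 0.5 nM and 8 nM.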

Compound 4, inhibition constant: 1 nM
For compound 4 the middle estimate is 2.0-fold (0.30 log units) above the measured one, and the stated range covers the measured number.
By their numbers in this assay, from the lowest: compound 1; then compound 4; then compound 2; then compound 3.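

In this assay the change from 4-(trifluoromethyl)phenyl to 3,4-difluorophenyl on the aromatic nitrogen gives a 12-fold lower number from compound 3 to compound 4 (1.09 log units; beyond the scatter) with the tert-butyl group held fixed, so this position can also move the number a long way downward, not only upward. Compared with the 3-chlorophenyl group, 3,4-difluorophenyl gives a 2.5-fold higher number from compound 1 to compound 4 (0.40 log units; beyond the scatter), which places the three groups in a clear order with the tert-butyl group in place: 3-chlorophenyl gives the lowest number, 3,4-difluorophenyl the middle one and 4-(trifluoromethyl)phenyl the highest. Compound 4 also isolates the group on the aromatic carbon, since tert-butyl in place of trifluoromethyl gives a 4.9-fold lower number from compound 2 to compound 4 (0.69 log units; beyond the scatter) with the 3,4-difluorophenyl group unchanged, so that site matters as well.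

As far as these compounds go, it remains open whether a phenyl ring carrying a methoxy group or a nitrile on this nitrogen, or a saturated cyclohexyl ring in place of the phenyl ring, would give a number as low as those of the halogen-bearing rings. Nothing given here bears on why these groups give different numbers.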